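The compounds below may be only part of what the source reports. "The series", "measured", "known", "first", "only" and "open" are said of these compounds alone.

Within this set, compound 1 `CCCCn1cnc2c(SC(C)C)nc(N)nc21` gives 120000 nM in an assay on isolated protein for binding affinity to Equilibrative nucleoside transporter 1 (Homo sapiens) (on this read-out higher numbers stand for weaker inhibition and lower numbers for stronger inhibition), and compound 2 `CC(C)Sc1nc(N)nc2c1ncn2[C@@H]1O[C@H](CO)[C@@H](O)[C@H]1O` gives 191000 nM in this assay. Compound 3 `Cc1c(CNc2ncnc3c2ncn3[C@@H]2O[C@H](CO)[C@@H](O)[C@H]2O)cccc1[N+](=O)[O-]` gives 427 nM in this assay, the lowest of the three numbers; both compound 1 and compound 2 stand beyond the scatter above it, compound 2 furthest of all.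

Compound 4 `O=[N+]([O-])c1cc(CNc2ncnc3c2ncn3[C@@H]2O[C@H](CO)[C@@H](O)[C@H]2O)ccc1Cl` differs from compound 3 by 4-chloro-3-nitrophenyl in place of 2-methyl-3-nitrophenyl on a saturated chain carbon bound to a nitrogen on an aromatic ring. For the measured compounds named here, no measured pair in the set isolates this change, so its size has no precedent here. The step from compound 3 to compound 4 is expected to be small, a 1.3-fold higher number from compound 3 to compound 4 (0.11 log units; within the scatter), at or near the edge of the scatter and without a firm direction. Compound 4 is therefore estimated at 550 nM in this assay, with a range from 130 nM to 2300 nM.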

Compound 4, half-maximal inhibitory concentration: 708 nM
The estimate for compound 4 lay 1.3-fold (0.11 log units) below the measured number; measured number inside the range.
By their numbers in this assay, from the lowest: compounds 3 and 4 (each within the scatter of the next); then compounds 1 and 2 (each within the scatter of the next).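

On a saturated chain carbon bound to a nitrogen on an aromatic ring, 4-chloro-3-nitrophenyl in place of 2-methyl-3-nitrophenyl gives a 1.7-fold higher number from compound 3 to compound 4 (0.22 log units; within the scatter) in this assay, so the two groups cannot be told apart on this read-out. The series' first step between compounds that differ in one place thus shows that this exchange leaves the number within the scatter. No supporting data bear on this result.

On these data alone, the step swaps two ring substituents at once, so their separate contributions stay open. Also open, as far as these compounds go, is how a carboxylic acid in place of the nitro group, or a longer chain at this place, would read.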